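Fluoro for methoxy on the arylsulfanyl of compound 2

The source may report more compounds than this note shows. Statements on the series, on what has been measured and on what is new or still open speak of the compounds shown alone.

Working notes on the series built around the shared core of compound 1, `CCOC(=O)[C@H](CCC(=O)O)NC(=O)c1ccc(Oc2nc3cc(N)cc(N)c3nc2-c2ccccc2)cc1`. In a functional assay on UO-31 cells (Homo sapiens) for inhibition, read by sulforhodamine B assay, with a stated time of 48 h (on this read-out lower numbers stand for stronger inhibition of growth and higher numbers for weaker inhibition of growth), compound 1 reaches only a limit of the assay, < 50200 nM. Compound 2, `COc1ccc(Sc2nc3cc(N)cc(N)c3nc2-c2ccccc2)cc1`, carries a (4-methoxyphenyl)sulfanyl group on the same core. In this assay compound 2 also gives only a limit, < 100000 nM. For the measured compounds named here, both values shown are thus limits, one sitting at the limit of < 100000 nM in this assay, at which 1 of the 2 values shown sits, and one at the limit of < 50200 nM in this assay, at which 1 of the 2 values shown sits, so no step between measured compounds can be drawn and compound 2 cannot be placed against compound 1 beyond that.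

Compound 3, `Nc1cc(N)c2nc(-c3ccccc3)c(Sc3ccc(F)cc3)nc2c1`, differs from compound 2 by fluoro in place of methoxy on an aromatic carbon. Going by the values given here, no comparable measured step exists in the set. With no evidence either way, the expectation is a step from compound 2 to compound 3 of about a step that the limit leaves unreadable from compound 2 to compound 3, none beyond the usual scatter. Compound 3 is therefore expected to give roughly 40000 nM in this assay, within 8000 nM to 100000 nM, and it may again return only a limit.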

Compound 3, concentration for total growth inhibition: < 100000 nM
Compound 3: a limit, no number (the forecaster's own chance of this, stated with the estimate: 50%); the middle value does not contradict the limit.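

In this assay compound 3 returns only a limit, < 100000 nM. For the compounds shown here, compound 2 also stands at a limit, so no step from compound 2 to compound 3 can be read. The compounds shown leave open whether fluoro in place of methoxy on an aromatic carbon changes inhibition of growth at all, and in which direction.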